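This account rests on a few compounds, and the source may have more. Where it says the series, first, only, none or still open, it means among the compounds named here.

The study compares three compounds that share one core and differ only in the group on a sulfonyl sulfur. Compound 1 `O=C(NCc1ccc(S(=O)(=O)C2CCOCC2)cc1)c1cc2ccncc2o1` carries oxan-4-yl there, and in an assay for inhibition of Nicotinamide phosphoribosyltransferase (Homo sapiens), with stated times of 15 min and 30 min (a lower number here means a stronger inhibitor, a higher number a weaker inhibitor), compound 1 gives 47 nM. Compound 2 `Cc1ccc(S(=O)(=O)c2ccc(CNC(=O)c3cc4ccncc4o3)cc2)cn1` carries 6-methylpyridin-3-yl instead, and in this assay compound 2 gives 11 nM. For the measured compounds named here, of the two numbers so far, compound 2 has the lowest, and its nearest neighbour is compound 1, with a step of a 4.3-fold lower number from compound 1 to compound 2 (0.63 log units; beyond the scatter).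

Compound 3 `CC(C)n1cc(S(=O)(=O)c2ccc(CNC(=O)c3cc4ccncc4o3)cc2)cn1` has not yet been measured. It differs from compound 2 in one place: 1-isopropyl-1H-pyrazol-4-yl in place of 6-methylpyridin-3-yl on a sulfonyl sulfur. Going by the values given here, the only measured step that touches this position is a 4.3-fold lower number from compound 1 to compound 2 (0.63 log units; beyond the scatter), which exchanged oxan-4-yl for 6-methylpyridin-3-yl. Here one aromatic group replaces another at the same place, and no measured pair shows such an exchange, so the data give no ground for a step of that size. In this assay a step within the scatter is therefore expected, a 1.4-fold higher number from compound 2 to compound 3 (0.13 log units; within the scatter). Compound 3 is accordingly estimated at 15 nM in this assay, with a range from 6 nM to 40 nM.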

Compound 3, half-maximal inhibitory concentration in the Nicotinamide phosphoribosyltransferase assay: 10 nM
Compound 3: the middle estimate sits 1.5-fold (0.18 log units) above what was measured; the range from low to high includes it.
By their numbers in the Nicotinamide phosphoribosyltransferase assay, from the lowest: compounds 3 and 2 (each within the scatter of the next); then compound 1.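

In the Nicotinamide phosphoribosyltransferase assay, one aromatic group in place of another on the sulfonyl sulfur gives only a 1.1-fold lower number from compound 2 to compound 3 (0.04 log units; within the scatter), whereas replacing oxan-4-yl with 1-isopropyl-1H-pyrazol-4-yl gives a 4.7-fold lower number from compound 1 to compound 3 (0.67 log units; beyond the scatter). Compound 2 and compound 3 thus both stand apart from compound 1, and this assay does not separate the six-membered aromatic ring with 1 hetero atom from the five-membered aromatic ring with 2 hetero atoms and its isopropyl group. The exchange that leaves this read-out within the scatter does, however, separate the two compounds in a physicochemical assay for solubility, measured as kinetic solubility, with a stated time of 24 h, at pH 7.4 (on this read-out higher numbers stand for higher solubility and lower numbers for lower solubility), where the step lies beyond the scatter: the measured solubility of compound 2, 47000 nM, and of compound 3, 12000 nM, a 3.9-fold lower number (0.59 log units; beyond the scatter). In the physicochemical assay compound 2 gives 47000 nM and compound 3 gives 12000 nM as measured.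

The compounds shown leave open whether an aromatic ring on the sulfonyl sulfur is needed for the stronger inhibition, or whether an open-chain group such as tert-butyl, or a cyclic amine such as piperidine, would serve as well. On these data alone, it also remains open whether a pyrazole carrying methyl in place of isopropyl, or a pyridine carrying a carboxylic acid, would hold the inhibition of compound 3 while giving a different solubility.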